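Amide variation on a sulfonylpiperazine core

The source may hold more compounds than are shown below. What is called first, only, known or untested is meant among the compounds shown, and "the series" means these compounds.

compound 1 `CCN(CC)C(=O)C(C)N1CCN(S(=O)(=O)c2ccc(C(C)(C)C)cc2)CC1`: > 40000 nM
compound 2 `C[C@@H](C(=O)N1CCCCC1)N1CCN(S(=O)(=O)c2ccc(C(C)(C)C)cc2)CC1`: > 40000 nM

Of the compounds shown here, two have been tested in an ADME assay on HepG2 cells (Homo sapiens) for inhibition, with a stated time of 48 h; on this read-out higher numbers stand for an effect only at larger amounts of compound and lower numbers for an effect already at smaller amounts. Compound 1 gives > 40000 nM, which is a limit of the assay and not a number. Compound 2 likewise gives > 40000 nM, again a limit. Within the data shown here, the only evidence is the limit of > 40000 nM in this assay, at which 2 of the 2 values shown sit; compound 1 thus stands where the one other measured compound stands, with no step between them to measure. Compound 3 `CC1CCN(C(=O)C(C)N2CCN(S(=O)(=O)c3ccc(C(C)(C)C)cc3)CC2)CC1` differs from compound 1 by 4-methylpiperidin-1-yl in place of diethylamino on a carbonyl carbon. Among the measured compounds shown here, no measured step informs this change, and the expected step of a number no higher from compound 1 to compound 3 (the limit leaves the size open) is estimated as none beyond the scatter. Compound 3 is expected at 40000 nM, with a range from 15000 nM to 100000 nM, most likely reported again only as a limit.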

Compound 3, half-maximal effective concentration: > 40000 nM
Compound 3: no number, only a limit; the forecaster's own chance of this, stated with the estimate: 85%; the middle value lies on the limit itself.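

Compound 3 gives only a limit of the assay, as compound 1 does, so no step between them can be read: the limit of > 40000 nM in this assay, at which 3 of the 3 values shown sit.

The compounds shown leave open whether any change of the amide on the shared core would give a readable number in this assay.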